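The source may report more compounds than this note shows. Statements on the series, on what has been measured and on what is new or still open speak of the compounds shown alone.

Measured in an assay on HL-60 cells for agonist activity at vitamin D3 receptor (Homo sapiens), read by microscopy, with a stated time of 96 h (on this read-out higher numbers stand for an effect only at larger amounts of compound and lower numbers for an effect already at smaller amounts), so far:
compound 1 `CCn1c(C(=O)NCCN)ccc1C(CC)(CC)c1ccc(OCC(=O)C(C)(C)C)c(C)c1`: 120 nM
compound 2 `CCn1c(C(=O)NCCN(C)C)ccc1C(CC)(CC)c1ccc(OCC(O)C(C)(C)C)c(C)c1`: 14 nM
compound 3 `C#CCNC(=O)c1ccc(C(CC)(CC)c2ccc(OCC(O)C(C)(C)C)c(C)c2)n1CC`: 240 nM

Compound 3 carries the highest number of the three; compound 1 sits within the scatter of it, compound 2 stands well apart. Compound 4 `CCn1c(C(=O)NCCN)ccc1C(CC)(CC)c1ccc(OCC(O)C(C)(C)C)c(C)c1` differs from compound 3 by aminomethyl in place of ethynyl on a saturated chain carbon bound to an amide-type nitrogen. Within the data shown here, the one step that bears on this is a 17-fold higher number from compound 2 to compound 3 (1.23 log units; beyond the scatter); read backwards, putting an amine in place of ethynyl gave a large fall. Compound 1 also carries the aminomethyl but otherwise differs from compound 4. Compound 1 gives 120 nM, while compound 2 gives 14 nM, so the primary amine need not match compound 2. For compound 4 a fall beyond the scatter is expected: a 6.0-fold lower number from compound 3 to compound 4 (0.78 log units; beyond the scatter). Compound 4 is estimated at 40 nM, range 12 nM to 130 nM.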

Compound 4, half-maximal effective concentration: 10 nM
For compound 4 the middle estimate is 4.0-fold (0.60 log units) above the measured one; measured number below the stated range.
By their numbers in this assay, from the lowest: compounds 4 and 2 (each within the scatter of the next); then compounds 1 and 3 (each within the scatter of the next).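

The gain at this position belongs to the amine end, not to the ethynyl end: aminomethyl in place of ethynyl gives (a 24-fold lower number from compound 3 to compound 4 (1.38 log units; beyond the scatter)). Amino and dimethylamino ends are not told apart (a 1.4-fold lower number from compound 2 to compound 4 (0.15 log units; within the scatter)), so methyl groups on that nitrogen are tolerated here, while the amine alone does not carry the result, as the 1-hydroxy-2,2-dimethylpropyl group in place of (tert-butyl)carbonyl shows (a 12-fold lower number from compound 1 to compound 4 (1.08 log units; beyond the scatter)). No measurement here accounts for these steps.

Still open, on these data alone, is whether a nitrogen is needed at the chain end at all, which a hydroxyl or a carboxylic acid there would test. Also open, as far as these compounds go, is how a longer chain, such as 3-aminopropyl, would compare.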